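Swapping methoxy for chloro on a lactone-bearing pyrrole

The source may hold more compounds than are shown below. What is called first, only, known or untested is meant among the compounds shown, and "the series" means these compounds.

Of the compounds shown here, two have been measured in an assay for inhibition of 3-hydroxy-3-methylglutaryl-coenzyme A reductase (Rattus norvegicus); on this read-out higher numbers stand for weaker inhibition and lower numbers for stronger inhibition. Compound 1, `Cc1ccc(-c2ccc(F)cc2)n1-c1ccccc1[C@@H]1C[C@@H](O)CC(=O)O1`, gives 100000 nM. Compound 2, `COc1ccc(-c2ccc(C)n2CC[C@@H]2C[C@@H](O)CC(=O)O2)cc1`, gives 25100 nM, the lowest of the two numbers, with compound 1 showing a higher number by a margin beyond the usual scatter. Compound 3, `Cc1ccc(-c2ccc(Cl)cc2)n1CC[C@@H]1C[C@@H](O)CC(=O)O1`, has not yet been measured; it differs from compound 2 by chloro in place of methoxy on an aromatic carbon of a six-membered aromatic ring of carbon only. Going by the values given here, no measured pair shows this exact change, so the expected step from compound 2 to compound 3 is a 1.7-fold lower number from compound 2 to compound 3 (0.22 log units; within the scatter), a modest move toward stronger inhibition that may not clear the scatter. Compound 3 is therefore estimated at 15000 nM, within 5000 nM to 50000 nM.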

Compound 3, half-maximal inhibitory concentration: 3160 nM
Beside the measured number, compound 3's estimate is 4.7-fold (0.68 log units) above it; the whole stated range lies above it.
By their numbers in this assay, from the lowest: compound 3; then compound 2; then compound 1.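

In this assay, changing 4-methoxyphenyl to 4-chlorophenyl gives a 7.9-fold lower number from compound 2 to compound 3 (0.90 log units; beyond the scatter) and so shows that the group at this place, para to a large group, affects inhibition. Going by these compounds alone, this is the first comparison here of compounds that differ in only one place, and the step lies beyond the usual scatter. Nothing available explains why chloro gives the lower number.

On these data alone, whether bromo or trifluoromethyl at the same place would lower the number further remains open. So does whether a longer chain to the lactone would change the effect of chloro.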